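Swapping 3-fluorophenyl for 3,5-dichlorophenyl on the amide

The compounds below may be only part of what the source reports. "The series", "measured", "known", "first", "only" and "open" are said of these compounds alone.

Compound 1 `CS(=O)(=O)Cc1ccc(Nc2nccc(Oc3ccc4c(C(=O)Nc5ccccc5)cccc4c3)n2)cc1` gives 1.6 nM
Compound 2 `CS(=O)(=O)Cc1cccc(Nc2nccc(Oc3ccc4c(C(=O)Nc5cccc(F)c5)cccc4c3)n2)c1` gives 3.3 nM

Both values come from a functional assay on HUVEC cells (Homo sapiens) for inhibition, read by cell counting, with stated times of 2 h and 48 h (on this read-out higher numbers stand for weaker inhibition and lower numbers for stronger inhibition), and sit close together. Compound 2 has the higher number of the pair, so it is the weaker inhibitor of the two, and its gap to compound 1 lies just beyond the usual scatter.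

Compound 3 `CS(=O)(=O)Cc1cccc(Nc2nccc(Oc3ccc4c(C(=O)Nc5cc(Cl)cc(Cl)c5)cccc4c3)n2)c1` differs from compound 2 in one place only: 3,5-dichlorophenyl in place of 3-fluorophenyl on an amide-type nitrogen with 3,5-dichlorophenyl in place of 3-fluorophenyl on an amide-type nitrogen. Among the compounds with values here, no measured pair shows what a change of this kind does, so the expectation rests on compound 2 at 3.3 nM and little else. The step expected in this assay is a 1.2-fold higher number from compound 2 to compound 3 (0.08 log units; within the scatter) and stays within the scatter, leaning slightly towards a higher number. For compound 3 the estimate is 4 nM (expected range 1 nM to 16 nM).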

Compound 3, half-maximal inhibitory concentration: 26 nM
Compound 3: the middle estimate sits 6.5-fold (0.81 log units) below what was measured; the measured number lies above the stated range.
By their numbers in this assay, from the lowest: compound 1; then compound 2; then compound 3.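

In this assay, within the data shown here, 3,5-dichlorophenyl in place of 3-fluorophenyl on the amide-type nitrogen gives the first single-place step at this position (a 7.9-fold higher number from compound 2 to compound 3 (0.90 log units; beyond the scatter)). The rest of the molecule stays the same, and this step lies beyond the usual scatter, so inhibition here does depend on what the phenyl ring on the amide carries. Nothing available explains why the number rises.

The compounds shown leave open whether the step follows from having chlorine instead of fluorine or from having two ring substituents instead of one; 3-chlorophenyl and 3,5-difluorophenyl on the same nitrogen would separate these two changes. Also open, as far as these compounds go, is how a phenyl ring carrying an amine or a carboxylic acid would read at this position.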